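Adding a methyl on the chain carbon of compound 2

This account rests on a few compounds, and the source may have more. Where it says the series, first, only, none or still open, it means among the compounds named here.

Compound 1, `CC(C(=O)N1CCN(c2ccccc2)CC1)N1C(=O)CCC1=O`, gives 50% in a functional assay on the whole organism (strain Swiss) with Mus musculus as the target, in the maximal electroshock model, with a stated time of 1 h, at a dose of 300 mg/kg by the intraperitoneal route; a lower number here means a weaker effect, a higher number a stronger effect of the compound at the dose given.
Compound 2, `CC(C(=O)N1CCN(c2ccc(C(F)(F)F)cc2)CC1)N1C(=O)CCC1=O`, gives 0% in this assay.

Of the two measured numbers, compound 2 stands lowest; its nearest neighbour is compound 1, and the step of a number 50 percentage points lower from compound 1 to compound 2 (beyond the scatter) was beyond the usual scatter. Compound 3, `CCC(C(=O)N1CCN(c2ccc(C(F)(F)F)cc2)CC1)N1C(=O)CCC1=O`, has not yet been measured. It differs from compound 2 by methyl in place of hydrogen on a saturated chain carbon, two bonds along the chain from an amide-type nitrogen in a ring and a carbonyl carbon. Among the measured compounds shown here, the only measured step, a number 50 percentage points lower from compound 1 to compound 2 (beyond the scatter), concerns a different change, at an aromatic carbon, so no measured step bears directly on this change on the saturated chain. For the measured compounds named here, what is known is only that compound 2 sits at the bottom of the scale in this assay, so the number cannot fall further; any movement must be upward or none at all. Without a comparable step in the data, the step from compound 2 to compound 3 is expected to be small, a number 10 percentage points higher from compound 2 to compound 3 (within the scatter), and within or only slightly beyond the scatter. Compound 3 is therefore estimated to give 10% in this assay, within a range from 0% to 40%.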

Compound 3, a percentage reported as activity, at one dose (the size of the read-out at that dose, not a potency): 0%
Compound 3: the middle estimate sits 10 percentage points above what was measured; measured number inside the range.
By their numbers in this assay, from the lowest: compounds 2 and 3 (each within the scatter of the next); then compound 1.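

In this assay, methyl in place of hydrogen on a saturated chain carbon, two bonds along the chain from an amide-type nitrogen in a ring and a carbonyl carbon, a change that also reads as methyl to ethyl, gives no change at the digits printed from compound 2 to compound 3 (within the scatter) and so adds no measurable effect at this dose in the presence of the trifluoromethyl group. This is the first look at this chain position, but the read-out remains at the bottom of its scale, where a further loss could not appear, so only a gain could have shown and none did. Nothing in the data shown offers an explanation for this outcome.

The result leaves open what the same change does on the core of compound 1, which gives 50% and so has room on the scale to show a change in either direction. It also leaves open whether a propyl chain or an amine on this chain carbon would lift the number above the bottom of the scale when the trifluoromethyl group is present.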